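This account rests on a few compounds, and the source may have more. Where it says the series, first, only, none or still open, it means among the compounds named here.

Measured so far:
compound 1 `COc1ccccc1C(=O)Nc1cccc(-c2oc3cc(-c4ccc(F)cc4)ccc3c(=O)c2O)c1` — in a functional assay on HepG2 cells (Homo sapiens) for antiproliferative activity, read by CCK-8 assay, with a stated time of 72 h (a lower number here means a stronger inhibitor, a higher number a weaker inhibitor), compound 1 gives 14500 nM
compound 2 `O=C(Nc1cccc(-c2oc3cc(-c4ccc(F)cc4)ccc3c(=O)c2O)c1)c1ccc(C(F)(F)F)cc1` — in this assay compound 2 gives 42700 nM

Compound 2 stands at the higher of the two numbers measured in this assay; its nearest neighbour is compound 1, and the step of a 2.9-fold higher number from compound 1 to compound 2 (0.47 log units; beyond the scatter) lies beyond the scatter. Compound 3 `COc1cccc(C(=O)Nc2cccc(-c3oc4cc(-c5ccc(F)cc5)ccc4c(=O)c3O)c2)c1` is not yet measured. It differs from compound 2 by 3-methoxyphenyl in place of 4-(trifluoromethyl)phenyl on a carbonyl carbon. Among the compounds with values here, the only measured step that bears on this change is a 2.9-fold higher number from compound 1 to compound 2 (0.47 log units; beyond the scatter), in which a methoxyphenyl gave way to the trifluoromethylphenyl and the number rose modestly. Within the data shown here, compound 3 reverses that exchange, though as 3-methoxyphenyl rather than 2-methoxyphenyl, and no measured pair tests that distinction. Compound 3 is therefore expected to give a lower number, a step of about a 2.1-fold lower number from compound 2 to compound 3 (0.33 log units; beyond the scatter). The estimate for compound 3 in this assay is 20000 nM, with a range from 8000 nM to 50000 nM.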

Compound 3, half-maximal inhibitory concentration: 9950 nM
For compound 3 the middle estimate is 2.0-fold (0.30 log units) above the measured one; low and high end bracket the measured number.
By their numbers in this assay, from the lowest: compounds 3 and 1 (each within the scatter of the next); then compound 2.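

In this assay, the step of a 4.3-fold lower number from compound 2 to compound 3 (0.63 log units; beyond the scatter) shows that the rise seen with 4-(trifluoromethyl)phenyl on the carbonyl carbon is not tied to compound 1 alone, since it also appears against a second methoxyphenyl. Within the data shown here, the step of a 1.5-fold lower number from compound 1 to compound 3 (0.16 log units; within the scatter) is the first reading on the two methoxyphenyl groups, and it does not tell 3-methoxyphenyl from 2-methoxyphenyl. No evidence is given on what lies behind these numbers.

Since the trifluoromethyl group is shown only as 4-(trifluoromethyl)phenyl, the compounds leave open whether the step follows the group itself or where it stands on the ring. Going by these compounds, what 4-methoxyphenyl, or a phenyl ring carrying an amine or a carboxylic acid, would give on this carbonyl carbon also stays open.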